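The source may hold more compounds than are shown below. What is called first, only, known or untested is meant among the compounds shown, and "the series" means these compounds.

The measured compounds:

Compound 1, `COc1cc(-c2nn(-c3cccc(NC(=O)Nc4cc(C(F)(F)F)cc(C(F)(F)F)c4)c3)cc2-c2ccncc2)ccc1Cl`: 2790 nM
Compound 2, `COc1cc(-c2nn(-c3cccc(NC(=O)c4cccc(C(F)(F)F)c4)c3)cc2-c2ccncc2)ccc1Cl`: > 50000 nM
Compound 3, `O=C(Nc1cccc(-n2cc(-c3ccncc3)c(-c3ccc(Cl)c(O)c3)n2)c1)Nc1ccc(Cl)c(Cl)c1`: > 32500 nM

All three were tested in a functional assay on CCRF-CEM cells (Homo sapiens) for inhibition, read by sulforhodamine B assay, with a stated time of 48 h; on this read-out lower numbers stand for stronger inhibition of growth and higher numbers for weaker inhibition of growth. Within the data shown here, compound 1 is the only one with a measured number, giving 2790 nM in this assay. For compound 2, this assay reports only a limit, > 50000 nM, and not a number; this is the limit (the limit of > 50000 nM in this assay, at which 1 of the 3 values shown sits). Compound 3 likewise yields only a limit, > 32500 nM, which is the limit (the limit of > 32500 nM in this assay, at which 1 of the 3 values shown sits). Compound 2 therefore stands among the two compounds whose growth inhibition was too weak to be read as a number, and below what compound 1 shows.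

Compound 4, `COc1cc(-c2nn(-c3cccc(NC(=O)c4ccc(Cl)c(C(F)(F)F)c4)c3)cc2-c2ccncc2)ccc1Cl`, has not been measured. It differs from compound 2 by chloro in place of hydrogen on an aromatic carbon. Among the measured compounds shown here, no pair of measured compounds differs in just this way, so there is no measured step to lean on. The step from compound 2 to compound 4 is expected to be small, an at least 1.2-fold lower number from compound 2 to compound 4 (0.09 log units; that floor lies within the scatter), and not clearly beyond the scatter in either direction. Compound 4 is thus estimated at 40000 nM in this assay, within a range from 10000 nM to 100000 nM, with a good chance that only a limit is reported again.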

Compound 4, concentration for total growth inhibition: > 32500 nM
Compound 4 gave a limit, no number; the forecaster's own chance of this, stated with the estimate: 65%; the middle value is on the limit's open side.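

Compound 2 and compound 4 each give only a limit in this assay, not a number, and the step between them cannot be read. The compounds shown leave open whether going from 3-(trifluoromethyl)phenyl to 4-chloro-3-(trifluoromethyl)phenyl changes growth inhibition at all, and in which direction.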